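Cyclopropyl replacing difluoromethyl on the alkene carbon

The source may report more compounds than this note shows. Statements on the series, on what has been measured and on what is new or still open speak of the compounds shown alone.

For the measured compounds named here, compound 2 `O=C(O)/C=C/c1ccc(/C(=C(\c2ccccc2)C(F)F)c2ccc3[nH]ncc3c2)cc1` gives 14 nM in a functional assay on MCF7 cells (Homo sapiens) for cytotoxicity, read by CellTiter-Glo, with a stated time of 5 days (on this read-out lower numbers stand for stronger inhibition and higher numbers for weaker inhibition), the highest of the two numbers so far. Going by the values given here, its nearest neighbour is compound 1 `O=C(O)/C=C/c1ccc(/C(=C(/CCF)c2ccccc2)c2ccc3[nH]ncc3c2)cc1`, which in this assay gives 2.1 nM; the step of a 6.7-fold higher number from compound 1 to compound 2 (0.82 log units; beyond the scatter) is the only measured step. Compound 3 `O=C(O)/C=C/c1ccc(/C(=C(\c2ccccc2)C2CC2)c2ccc3[nH]ncc3c2)cc1` differs from compound 2 by cyclopropyl in place of difluoromethyl on a double-bonded chain carbon bound to an aromatic carbon and a double-bonded chain carbon. Among the compounds with values here, no measured pair covers cyclopropyl at this position, so the one step that bears on the change is the replacement of 2-fluoroethyl by difluoromethyl, which moved the number by a 6.7-fold higher number from compound 1 to compound 2 (0.82 log units; beyond the scatter). Since the substituent on that double-bonded chain carbon has shifted the read-out beyond the scatter once, a change of similar order is expected here, and a lower number for compound 3 is taken as somewhat more likely than a higher one, with the estimated step being a 2.8-fold lower number from compound 2 to compound 3 (0.45 log units; beyond the scatter). Compound 3 is therefore expected to give about 5 nM in this assay, with a range of 1.5 nM to 17 nM.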

Compound 3, half-maximal inhibitory concentration: 13 nM
Compound 3: middle estimate off by 2.6-fold (0.41 log units), on the low side; measured number inside the range.
By their numbers in this assay, from the lowest: compound 1; then compounds 3 and 2 (each within the scatter of the next).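

In this assay, the change to cyclopropyl gives a 1.1-fold lower number from compound 2 to compound 3 (0.03 log units; within the scatter) at this double-bonded chain carbon, so difluoromethyl and cyclopropyl are not separated despite sharing no ring or fluorine. With a 6.2-fold higher number from compound 1 to compound 3 (0.79 log units; beyond the scatter) alongside a 6.7-fold higher number from compound 1 to compound 2 (0.82 log units; beyond the scatter) in the same direction, compound 1 with its 2-fluoroethyl group keeps the lowest number of the three, and both other groups stand apart from it beyond the scatter. No measurement at hand accounts for this difference.

On these data alone, it remains open whether the low number of compound 1 depends on the fluorine of 2-fluoroethyl or on the chain itself, which an unfluorinated ethyl group would address. Also open, as far as these compounds go, is how a longer chain such as 3-fluoropropyl, or an amine on the chain, would read at this carbon.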